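The source may hold more compounds than are shown below. What is called first, only, known or untested is meant among the compounds shown, and "the series" means these compounds.

Compound 2, with the structure `O=C(Cc1cccnc1)c1cc2cc(O)ccc2[nH]1`, gives in an in vitro assay on P815B cells for inhibition of Indoleamine 2,3-dioxygenase 1 (Mus musculus), tested at 20 uM (a lower number here means less inhibition, a higher number more inhibition at the concentration tested (going by the name of the read-out)), only a report of "not active", so no number stands for it, and the piece has no single figure to place it on a scale. Compound 1, with the structure `O=C(Cc1cccnc1)c1cc2cc(F)ccc2[nH]1`, carries fluoro where compound 2 carries hydroxy; in this assay compound 1 gives 24%, while compound 2 gives "not active" (no number reported). Compound 3, with the structure `O=C(Cc1cccnc1)c1cc2cc(Cl)ccc2[nH]1`, has not yet been measured. Against compound 2 it differs in one place: chloro in place of hydroxy on an aromatic carbon. For the measured compounds named here, the chloro of compound 3 and the fluoro of compound 1 are both halogens, and the only compound in this set that yields a number, compound 1, does so with a halogen at that position. Going by the values given here, since compound 2 reports no number, no step can be computed, but an upward move beyond the scatter in this assay is expected for compound 3 relative to compound 2. Compound 3 is therefore estimated to give 25% in this assay, within a range from 5% to 50%, with some chance that it too is reported only as not active.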

Compound 3, a percentage reported as inhibition, at one concentration (the size of the read-out at that concentration, not a potency): 24%
The estimate for compound 3 lay 1 percentage points above the measured number, within the range that was stated.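

In this assay, chloro in place of fluoro on this aromatic carbon gives no change at the digits printed from compound 1 to compound 3 (within the scatter), so the two halogens cannot be told apart at this position in this read-out. For the compounds shown here, compound 1 was until now the only compound with a number, and compound 3 at 24% adds a second halogen compound with one, while compound 2, which carries hydroxy in the same place, gives "not active" (no number reported); the step between compound 2 and either halogen compound cannot be read, since compound 2 has no number, and the contrast rests on this report alone. Nothing at hand accounts for the match between the two halogens or for the report on the hydroxy compound.

The compounds shown leave open whether bromo or iodo at this position would fall in line with the fluoro and chloro compounds in this assay, or whether the match ends with these two halogens. They also leave open how a methoxy group, an amine or a methyl group in the same place would read, and so whether the report for compound 2 belongs to hydroxy alone or extends to other non-halogen groups.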